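Fluoro in place of methyl on compound 2

The source may report more compounds than this note shows. Statements on the series, on what has been measured and on what is new or still open speak of the compounds shown alone.

Of the compounds shown here, two with a shared core have been measured in a functional assay on HepG2 cells (Homo sapiens) for antiproliferative activity, read by MTT assay, with a stated time of 24 h; a higher number here means a weaker inhibitor, a lower number a stronger inhibitor. There, compound 1 `Cc1ccc(-c2nn(-c3ccccc3)cc2-c2nc3ccccc3n2S(=O)(=O)c2ccc(C)cc2)cc1` gives 520 nM and compound 2 `Cc1ccc(-c2nn(-c3ccccc3)cc2-c2nc3ccccc3n2S(=O)(=O)c2cc(C)ccc2C)cc1` gives 460 nM. These two values lie within the scatter of each other, so compound 2 stands level with compound 1 on the numbers available.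

The next compound, compound 3 `Cc1ccc(C)c(S(=O)(=O)n2c(-c3cn(-c4ccccc4)nc3-c3ccc(F)cc3)nc3ccccc32)c1`, differs from compound 2 by fluoro in place of methyl on an aromatic carbon, para to a large group, which turns 4-methylphenyl into 4-fluorophenyl. Among the compounds with values here, only one measured step exists, a 1.1-fold lower number from compound 1 to compound 2 (0.05 log units; within the scatter). It replaces 4-methylphenyl with 2,5-dimethylphenyl on a sulfonyl sulfur, which is a different place, so it bears on the new change only indirectly. Within the data shown here, no measured step covers a change at the place now altered. With compound 2 at 460 nM as the anchor, no shift beyond the scatter is expected in this assay, and no direction can be favoured. The estimated move is a 1.0-fold lower number from compound 2 to compound 3 (0.01 log units; within the scatter). For compound 3 the expected value is 450 nM, with an estimated range from 200 nM to 1000 nM.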

Compound 3, half-maximal inhibitory concentration: 410 nM
For compound 3 the middle estimate is 1.1-fold (0.04 log units) above the measured one, within the range that was stated.
By their numbers in this assay, from the lowest: compounds 3, 2 and 1 (each within the scatter of the next).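

The exchange of 4-methylphenyl for 4-fluorophenyl is the first change shown at this place on the shared core, and in this assay it reads as a step within the scatter (a 1.1-fold lower number from compound 2 to compound 3 (0.05 log units; within the scatter)), so fluoro in place of methyl on this aromatic carbon, para to a large group, gives no difference that can be told from repeat measurement in this pair. The earlier step, on the sulfonyl sulfur, also lies within the scatter (a 1.1-fold lower number from compound 1 to compound 2 (0.05 log units; within the scatter)), so neither of the two places varied among these compounds has yet given a readable difference. Nothing in the available data offers an account of why this exchange leaves the numbers level.

The compounds shown leave open whether a different kind of group at this place, such as an amine, a carboxylic acid or a longer chain, would give a step beyond the scatter. On these data alone, it also remains open whether methyl and fluoro would read alike with the 4-methylphenyl on the sulfonyl sulfur of compound 1, since this pair carries 2,5-dimethylphenyl there.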